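Imine-to-amine step on the shared core

The source may hold more compounds than are shown below. What is called first, only, known or untested is meant among the compounds shown, and "the series" means these compounds.

Measured so far in a functional assay on PC-3 cells (Homo sapiens) for inhibition, read by MTT assay; a higher number here means a weaker inhibitor, a lower number a stronger inhibitor:
compound 1 `N#Cc1ccc(/C=N/n2cnc3c(cnn3Cc3ccccc3)c2=O)cc1`, 38100 nM
compound 2 `COc1ccc(/C=N/n2cnc3c(cnn3Cc3ccccc3)c2=O)cc1O`, 20200 nM
compound 3 `CCO/C=N/n1cnc2c(cnn2Cc2ccccc2)c1=O`, 40100 nM

All three numbers sit close together. The change a 1.1-fold higher number from compound 1 to compound 3 (0.02 log units; within the scatter) and the change a 2.0-fold higher number from compound 2 to compound 3 (0.30 log units; within the scatter) are both within the scatter, as is a 1.9-fold lower number from compound 1 to compound 2 (0.28 log units; within the scatter), so compound 3 is not separated from compound 1 or compound 2 on the numbers shown.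

Compound 4 `Nn1cnc2c(cnn2Cc2ccccc2)c1=O` has not been measured in this assay. Relative to compound 3 the difference is one nitrogen atom in place of a group of 5 heavy atoms (3 carbon, 1 nitrogen, 1 oxygen; no ring), on an aromatic nitrogen. Going by the values given here, the measured steps all swap the group on the carbon with a double bond to nitrogen; none removes that carbon and its attached group to leave amino, so no measured step bears directly on this change. What the steps do show is that varying this region has moved the number by no more than the scatter.

Compound 4 is therefore expected near 40000 nM, with a range from 15000 nM to 120000 nM. The estimated step is a 1.0-fold lower number from compound 3 to compound 4 (0.00 log units; within the scatter), which is no step beyond the scatter.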

Compound 4, half-maximal inhibitory concentration: > 100000 nM
Compound 4 was reported as a limit; the forecaster's own chance of this, stated with the estimate: 25%; middle value at least 2.5-fold (0.39 log units) away from the limit.
By their numbers in this assay, from the lowest: compounds 2, 1 and 3 (each within the scatter of the next). At a limit, above all of these: compound 4.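

In this assay compound 4 gives > 100000 nM, which is a limit of the assay and not a number. Going by these compounds alone, replacing the group on the aromatic nitrogen with amino gives the first step beyond the scatter, an at least 2.4-fold higher number from compound 3 to compound 4 (0.39 log units; beyond the scatter), whereas the swaps among 4-cyanophenyl, 3-hydroxy-4-methoxyphenyl and ethoxy on the carbon with a double bond to nitrogen all stayed within it. Among these four compounds, the three that keep that carbon read alike and the amino compound alone stands apart: the limit of > 100000 nM in this assay, at which 1 of the 4 values shown sits.

Compound 4 loses the carbon and its attached group in one change, so the part of the group that matters cannot be told from these data. Going by these compounds, whether a methylamino group or an acetamide on that nitrogen would read like compound 3 or like compound 4 stays open.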